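Fluoro to Bromo on a Potent Antiproliferative Nucleoside

The source may hold more compounds than are shown below. What is called first, only, known or untested is meant among the compounds shown, and "the series" means these compounds.

Measured compounds in a functional assay on L1210 cells (Mus musculus) for antiproliferative activity, read by cell counting, with a stated time of 48 h (on this read-out lower numbers stand for stronger inhibition and higher numbers for weaker inhibition), are as follows.
compound 1 `C#C[C@@]1(O)[C@@H](CO)O[C@@H](n2cnc3c(-c4ccccc4)ncnc32)[C@@H]1O` gives > 250000 nM as a limit
compound 2 `C#C[C@@]1(O)[C@@H](CO)O[C@@H](n2cnc3c(-c4ccc(C)cc4)ncnc32)[C@@H]1O` gives 205000 nM as a number
compound 3 `C#C[C@@]1(O)[C@@H](CO)O[C@@H](n2cc(F)c3c(N)ncnc32)[C@@H]1O` gives 35 nM as a number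

Compound 3 gives 35 nM as the lowest number shown in this assay while compound 2 gives 205000 nM as the only other number. Compound 1 gives > 250000 nM as a limit of the assay and not a number.

Compound 4 `C#C[C@@]1(O)[C@@H](CO)O[C@@H](n2cc(Br)c3c(N)ncnc32)[C@@H]1O` has not yet been measured. It differs from compound 3 at one place bromo in place of fluoro on an aromatic carbon with bromo in place of fluoro on an aromatic carbon.

Within the data shown here, the one measured step is an at least 1.2-fold lower number from compound 1 to compound 2 (0.08 log units; that floor lies within the scatter) for methyl in place of hydrogen on an aromatic carbon, and it involves neither fluoro nor bromo. It is therefore a weak guide, and it gives no direction for this change. No step beyond the scatter is expected, although the uncertainty is wide. The estimated step is a 1.4-fold higher number from compound 3 to compound 4 (0.15 log units; within the scatter) in this assay on this limited evidence. Compound 4 is expected at 50 nM with an estimated range from 8 nM to 400 nM in this assay once it is measured.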

Compound 4, half-maximal inhibitory concentration: 28 nM
For compound 4 the middle estimate is 1.8-fold (0.25 log units) above the measured one; the measured number falls inside the stated range.
By their numbers in this assay, from the lowest: compounds 4 and 3 (each within the scatter of the next); then compound 2. At a limit, above all of these: compound 1.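

In this assay bromo in place of fluoro on an aromatic carbon gives a 1.3-fold lower number from compound 3 to compound 4 (0.10 log units; within the scatter) and is the first step shown at this position, two ring bonds from the ring nitrogen. It shows that this read-out does not tell the two halogens apart here, so the low number seen with fluoro in compound 3 does not depend on fluoro alone and is kept in compound 4 with bromo. The earlier step concerned methyl at another place on a different set of compounds and gave no view of this position.

The compounds shown leave open how hydrogen, a nitrile, an amine or a carboxylic acid would read at this position, and so how far the tolerance seen with the two halogens extends. Nothing shown bears on the reason that compound 3 and compound 4 read alike.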